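The compounds below may be only part of what the source reports. "The series", "measured", "known", "first", "only" and "open" are said of these compounds alone.

Measured so far:
compound 1 `CC1=C(CC/C(C)=C/CC/C(C)=C/C[C@@H](O)C2=CC(=O)OC2)C(C)(C)CCC1`: > 10000 nM
compound 2 `CC1=C(CC/C(C)=C/CC/C(C)=C/CCC2=CC(=O)OC2O)C(C)(C)CCC1O`: > 10000 nM

In a functional assay on MDA-MB-231 cells (Homo sapiens) for antiproliferative activity, read by sulforhodamine B assay, with a stated time of 48 h (on this read-out lower numbers stand for stronger inhibition and higher numbers for weaker inhibition), compound 1 gives only a limit of the assay, > 10000 nM. In this assay compound 2 likewise gives only a limit, > 10000 nM. Compound 2 thus stands at the limit of > 10000 nM in this assay, at which 2 of the 2 values shown sit, with no number that sets it apart. Compound 3 `CC1=C(CC/C(C)=C/CC/C(C)=C/CCC2=CC(=O)OC2O)C(C)(C)CCC1` has not yet been measured in this assay; it differs from compound 2 by hydrogen in place of hydroxy on a saturated ring carbon. Going by the values given here, no step between measured compounds is known here, so in this assay no shift beyond the usual scatter is expected from this change. Compound 3 is expected to give about 10000 nM, within 3000 nM to 30000 nM, most likely again only a limit. The estimated step is a number no higher from compound 2 to compound 3 (the limit leaves the size open).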

Compound 3, half-maximal inhibitory concentration: 4500 nM
The estimate for compound 3 lay 2.2-fold (0.35 log units) above the measured number, within the range that was stated.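

In this assay, hydrogen in place of hydroxy on a saturated ring carbon gives an at least 2.2-fold lower number from compound 2 to compound 3 (0.34 log units; beyond the scatter), so this ring position can affect the read-out. A different group of 8 heavy atoms on a saturated chain carbon bound to a double-bonded chain carbon gives an at least 2.2-fold lower number from compound 1 to compound 3 (0.34 log units; beyond the scatter). Compound 3 alone gives a number, while the other two compounds give only a limit: the limit of > 10000 nM in this assay, at which 2 of the 3 values shown sit.

Going by these compounds, the full size of both steps stays open, as a limit is not a number. On these data alone, whether an amine or a methoxy group on this ring carbon would lower the number also remains open.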